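Methoxy for Dimethylamino: Cytotoxicity Expected to Stay at Limit

The source may hold more compounds than are shown below. What is called first, only, known or untested is meant among the compounds shown, and "the series" means these compounds.

Compound 1 `CN(C)c1ccc(NCc2cncn2Cc2ccc(-c3ccccc3)cc2)cc1-c1ccccc1` gives > 1000 nM in a toxicity assay on NIH3T3 cells (Mus musculus) for cytotoxicity, read by resazurin assay; a higher number here means that more compound is needed for the effect, a lower number that less compound is needed.
Compound 2 `COC(=O)c1ccc(NCc2cncn2Cc2ccc(F)cc2)cc1-c1ccccc1` gives "not determined" (no result reported) in this assay.
Compound 3 `COC(=O)c1ccc(NCc2cncn2Cc2cccc(C(C)(C)C)c2)cc1-c1ccccc1` gives > 1000 nM in this assay.

Compound 1 stands only at a limit in this assay, not at a number. Compound 3 likewise sits at a limit in this assay. For compound 2 no result in this assay was reported. Taken together the data show (the limit of > 1000 nM in this assay, at which 2 of the 3 values shown sit). Compound 4 `COc1ccc(NCc2cncn2Cc2ccc(-c3ccccc3)cc2)cc1-c1ccccc1` carries methoxy in place of dimethylamino on an aromatic carbon. Within the data shown here, no step between measured compounds is available to size this change, so in this assay no shift beyond the usual scatter is expected, in either direction. Compound 4 is therefore estimated at about 3000 nM, within 800 nM to 20000 nM, most likely reported again only as a limit. The expected step that the limit leaves unreadable from compound 1 to compound 4 stays within the scatter.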

Compound 4, half-maximal effective concentration: > 1000 nM
Compound 4 was reported as a limit (the forecaster's own chance of this, stated with the estimate: 80%); the middle value does not contradict the limit.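

Compound 1 and compound 4 both stand only at a limit in this assay, so no step between them can be read: the limit of > 1000 nM in this assay, at which 3 of the 4 values shown sit.

The compounds shown leave open whether methoxy and dimethylamino differ at all in this assay.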